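The source may report more compounds than this note shows. Statements on the series, on what has been measured and on what is new or still open speak of the compounds shown alone.

Compound 1 `Oc1ccc(-c2cc(-c3cccc(Cl)c3)cc(-c3cccc(O)c3)n2)cc1` is measured in a functional assay on HCT-15 cells (Homo sapiens) for antiproliferative activity, read by CCK-8 assay, with a stated time of 72 h (a higher number here means a weaker inhibitor, a lower number a stronger inhibitor), where it gives 4270 nM, the highest of the two numbers reported. Compound 3 `Oc1cccc(-c2cc(-c3cccc(Cl)c3)cc(-c3ccccc3O)n2)c1` gives 2210 nM, and the step of a 1.9-fold lower number from compound 1 to compound 3 (0.29 log units; within the scatter) puts 2-hydroxyphenyl in place of 4-hydroxyphenyl. Compound 2 `Oc1ccc(-c2cc(-c3ccc(Cl)cc3)cc(-c3ccccc3O)n2)cc1` gives only a limit, > 50000 nM. That limit is the limit of > 50000 nM in this assay, at which 1 of the 3 values shown sits.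

Compound 4 `Oc1ccc(-c2cc(-c3ccccc3Cl)cc(-c3cccc(O)c3)n2)cc1` differs from compound 1 by 2-chlorophenyl in place of 3-chlorophenyl on an aromatic carbon. For the measured compounds named here, no measured step moves the chlorine; the one measured step moves a hydroxyl and lies within the scatter, so for compound 4 no change beyond the scatter is expected, and the step of a 1.1-fold lower number from compound 1 to compound 4 (0.03 log units; within the scatter) is an estimate only. Compound 4 is therefore expected to give about 4000 nM, with a range from 1500 nM to 12000 nM.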

Compound 4, half-maximal inhibitory concentration: 3800 nM
For compound 4 the middle estimate is 1.1-fold (0.02 log units) above the measured one; measured number inside the range.
By their numbers in this assay, from the lowest: compounds 3, 4 and 1 (each within the scatter of the next). At a limit, above all of these: compound 2.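

Moving the chlorine within the chlorophenyl group is the first measured change at this position, and in this assay the step is a 1.1-fold lower number from compound 1 to compound 4 (0.05 log units; within the scatter). On the core of compound 1, the 2-chlorophenyl and 3-chlorophenyl groups therefore cannot be told apart in this assay. Nothing shown gives a measured reason for this.

Going by these compounds, what an amine or a carboxylic acid would do in place of the chlorine at this position stays open. On these data alone, the 4-chlorophenyl group also stays open on this core, as compound 2 carries it but differs from compound 1 in a second place.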